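Working notes on compound 3 and compound 4

The source may hold more compounds than are shown below. What is called first, only, known or untested is meant among the compounds shown, and "the series" means these compounds.

In a functional assay on MCF7 cells (Homo sapiens) for inhibition, read by sulforhodamine B assay, with a stated time of 48 h (on this read-out higher numbers stand for weaker inhibition and lower numbers for stronger inhibition), compound 1 `CCOC(=O)CCO/N=C(/c1ccc(OC)c(OC)c1OC)c1cccc2ccccc12` gives > 20000 nM, which is a limit of the assay and not a number. Compound 2 `COc1ccc(C(O)(Cc2ccc(C)cc2)c2cccc3ccccc23)c(OC)c1OC` in this assay gives > 20000 nM, likewise a limit. Compound 3 `COc1ccc(C(c2ccc(OCCO)cc2)c2cccc3ccccc23)c(OC)c1OC` in this assay gives > 20000 nM, again a limit. Among the measured compounds shown here, compound 3 therefore cannot be placed against the others on these numbers: every value shown sits at the limit of > 20000 nM in this assay, at which 3 of the 3 values shown sit, and no step between measured compounds can be read from them.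

Compound 4 `COc1ccc(C(c2ccc(OCC(=O)O)cc2)c2cccc3ccccc23)c(OC)c1OC` differs from compound 3 by carboxy in place of hydroxymethyl on a saturated chain carbon bound to an oxygen on an aromatic ring. For the measured compounds named here, no measured pair bears on a change of this kind, so nothing points to a step beyond the scatter in this assay in either direction, and the likeliest outcome is that compound 4 also returns only a limit. The estimate for compound 4 in this assay is 30000 nM, with a range from 8000 nM to 100000 nM. The expected step is a step that the limit leaves unreadable from compound 3 to compound 4, which amounts to no change beyond the scatter.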

Compound 4, half-maximal inhibitory concentration: > 20000 nM
Compound 4: only a limit was reported; the forecaster's own chance of this, stated with the estimate: 85%; the middle value does not contradict the limit.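

Among the compounds shown here, compound 3 and compound 4 both return only limits in this assay, so no step between them can be read. The compounds shown leave open whether any structural change here alters inhibition, and how these compounds rank, as every value sits at one limit: the limit of > 20000 nM in this assay, at which 4 of the 4 values shown sit.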